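This account rests on a few compounds, and the source may have more. Where it says the series, first, only, none or still open, it means among the compounds named here.

Measured so far:
compound 1, `COc1cc(/C=C/C(=O)C2=C(/C=C/c3ccc(O)c(OC)c3)NC(=O)NC2c2ccccc2)ccc1O`, 40.2%
compound 2, `COc1cc(/C=C/C(=O)C2=C(/C=C/c3ccc(O)c(OC)c3)NC(=O)NC2c2ccccc2Cl)ccc1O`, 55.5%
compound 3, `COc1cc(/C=C/C(=O)C2=C(/C=C/c3ccc(O)c(OC)c3)NC(=S)NC2c2c(Cl)cccc2Cl)ccc1O`, 50.2%

All three were tested in a functional assay, with a stated time of 20 min, tested at 50 uM; on this read-out lower numbers stand for a weaker effect and higher numbers for a stronger effect at the one concentration tested. Compound 2 and compound 1 differ in one place only, (hydrogen in place of chloro on an aromatic carbon), and this change gave a number 15.3 percentage points lower from compound 2 to compound 1 (beyond the scatter). Compound 3 has a different core from compound 2; the difference between the two cores is not broken down here, and the two values lie within the scatter of one another.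

Compound 4, `COc1cc(/C=C/C(=O)C2=C(/C=C/c3ccc(O)c(OC)c3)NC(=S)NC2c2ccccc2Cl)ccc1O`, has not yet been measured. It differs from compound 3 by hydrogen in place of chloro on an aromatic carbon. Among the compounds with values here, this is the same kind of change as the one from compound 2 to compound 1, but not the same: in compound 3 the place is also meta to a chloro group, and after the change one chloro still remains. Because the step of a number 15.3 percentage points lower from compound 2 to compound 1 (beyond the scatter) was a lowering beyond the scatter, a lowering is expected here too, though a somewhat smaller one is estimated, since a chloro stays behind. The expected step is a number 8.2 percentage points lower from compound 3 to compound 4 (within the scatter). In this assay compound 4 is estimated to give about 42%, with a likely range from 30% to 55%.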

Compound 4, a percentage reported as activity, at one concentration (the size of the read-out at that concentration, not a potency): 60%
Compound 4: the middle estimate sits 18 percentage points below what was measured; the whole stated range lies below it.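

In this assay, replacing one chloro with hydrogen, which turns the 2,6-dichlorophenyl group into the 2-chlorophenyl group, gave a number 9.8 percentage points higher from compound 3 to compound 4 (within the scatter), a step too small to tell from no change. Set beside the earlier step, the same kind of change does not carry over from one core to the other: the same change on two cores in this assay, a number 15.3 percentage points lower (beyond the scatter) from compound 2 to compound 1 and a number 9.8 percentage points higher (within the scatter) from compound 3 to compound 4, 25.1 percentage points apart, beyond the scatter of two such steps. So a step read on one core cannot simply be applied to the other core in this series, but this does not show what lies behind the gap, as it rests on only two pairs that differ in the core and also in whether a chloro stays on the ring.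

From the compounds shown here alone, it remains open what a fluoro, a nitrile or an amine would do in place of that chloro on either core. Also open, going by these compounds, is what a plain phenyl group would give on the core of compound 4, which would set the very same step, from 2-chlorophenyl to phenyl, on both cores.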